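Fluoro for hydrogen on the cinnamate ester of compound 3

The compounds below may be only part of what the source reports. "The series", "measured", "known", "first", "only" and "open" are said of these compounds alone.

Three compounds of the series have numbers in a functional assay on Jurkat cells (Homo sapiens) for antiproliferative activity, read by MTT assay, with a stated time of 6 days; a higher number here means a weaker inhibitor, a lower number a stronger inhibitor. Compound 1 `CC(=O)O[C@@H]1C=CC(=O)O[C@@H]1[C@@H](COC(=O)c1ccc(Cl)cc1)OC(C)=O` gives 24400 nM, compound 2 `CC(=O)O[C@@H]1C=CC(=O)O[C@@H]1[C@@H](COC(=O)c1ccc([N+](=O)[O-])cc1)OC(C)=O` gives 7450 nM, and compound 3 `O=C1C=C[C@@H](OCc2ccccc2)[C@@H]([C@@H](COC(=O)/C=C/c2ccccc2)OCc2ccccc2)O1` gives 4960 nM. Compound 3 holds the lowest of the three numbers; its gap to compound 2 is within the scatter, while its gap to compound 1 lies beyond it. Compound 4 `O=C1C=C[C@@H](OCc2ccccc2)[C@@H]([C@@H](COC(=O)/C=C/c2ccc(F)cc2)OCc2ccccc2)O1` differs from compound 3 by fluoro in place of hydrogen on an aromatic carbon. Going by the values given here, the only measured step that exchanges one group for another on an aromatic carbon is a 3.3-fold lower number from compound 1 to compound 2 (0.52 log units; beyond the scatter); it sits on a different ester and swaps a different pair of groups, so it bears on the present change only loosely and shows the largest shift such an exchange has given. Among the compounds with values here, no measured step exchanges fluoro for hydrogen. A small step is therefore expected, a 1.1-fold lower number from compound 3 to compound 4 (0.04 log units; within the scatter), with no direction that reaches beyond the scatter. Compound 4 is estimated at 4500 nM, within a range from 2000 nM to 10000 nM.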

Compound 4, half-maximal inhibitory concentration: 4160 nM
The estimate for compound 4 lay 1.1-fold (0.03 log units) above the measured number, within the range that was stated.
By their numbers in this assay, from the lowest: compounds 4, 3 and 2 (each within the scatter of the next); then compound 1.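

In this assay, fluoro on an aromatic carbon para to a large group gives a 1.2-fold lower number from compound 3 to compound 4 (0.08 log units; within the scatter), so this place on the phenyl of the 2-phenylethenyl ester carries the exchange with no step beyond the scatter. Going by these compounds alone, this is the first reading of any exchange on that ester, and the first of fluoro for hydrogen; the earlier step, a 3.3-fold lower number from compound 1 to compound 2 (0.52 log units; beyond the scatter), concerns another ester and another pair of groups, so the two steps form no trend. Nothing on hand accounts for the size of the new step.

On these data alone, whether a larger group at this place, such as methoxy, an amine or a carboxylic acid, would move the number beyond the scatter stays open. Also open, as far as these compounds go, is whether a longer chain in place of 2-phenylethenyl would leave the number as little changed.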